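The source may hold more compounds than are shown below. What is called first, only, known or untested is meant among the compounds shown, and "the series" means these compounds.

Of the compounds shown here, three have been measured in a functional assay on NCI-H460 cells (Homo sapiens) for antiproliferative activity, read by CCK-8 assay, with a stated time of 72 h, tested at 8 uM; on this read-out higher numbers stand for a stronger effect at the one concentration tested and lower numbers for a weaker effect. Compound 1, `COC(CCn1cnc2c(NCc3ccc(C(=O)Nc4ccccc4N)cc3)nc(Cl)nc21)OC`, gives 51.2%. Compound 2, `CCCCn1cnc2c(Nc3cccc(Cl)c3)nc(NCOCc3ccc(/C=C/C(=O)Nc4ccccc4N)cc3)nc21`, gives 51.1%, a number within the usual scatter of that of compound 1, so the two cannot be told apart on this read-out. Compound 3, `Nc1ccccc1NC(=O)c1ccc(Cn2cnc3c(Nc4ccccc4)nc(Cl)nc32)cc1`, gives 77.8%, which lies beyond the scatter above the number of compound 1. On the three numbers, compound 1 stands second highest, with compound 2 right beside it and compound 3 clearly above it.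

Compound 4, `CCCCn1cnc2c(NCc3ccc(C(=O)Nc4ccccc4N)cc3)nc(Cl)nc21`, has not yet been measured. It differs from compound 1 in one place: ethyl in place of dimethoxymethyl on a saturated chain carbon, two bonds along the chain from an aromatic nitrogen. Cut one bond further out, the same change reads 3,3-dimethoxypropyl to butyl. Among the compounds with values here, no measured pair shows exactly this change, so the size of the step cannot be read from the data. Compound 2 also carries a butyl chain on an aromatic nitrogen, but it differs from compound 1 in more than one place, and its value is within the scatter of that of compound 1. The step of a number 2.8 percentage points higher from compound 1 to compound 4 (within the scatter) is expected to be small, in either direction, and not clearly beyond the scatter. Compound 4 is therefore expected to give 54%, with a range from 35% to 73%.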

Compound 4, a percentage reported as inhibition, at one concentration (the size of the read-out at that concentration, not a potency): 23.7%
The estimate for compound 4 lay 30.3 percentage points above the measured number, outside the stated range (below it).
By their numbers in this assay, from the lowest: compound 4; then compounds 2 and 1 (each within the scatter of the next); then compound 3.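

In this assay, ethyl in place of dimethoxymethyl on a saturated chain carbon, two bonds along the chain from an aromatic nitrogen, gives a step of a number 27.5 percentage points lower from compound 1 to compound 4 (beyond the scatter). This shows that the chain at this position is not a neutral spectator: with the rest of the molecule unchanged, 3,3-dimethoxypropyl and butyl cannot be swapped without a clear change in the read-out. The change alters several things at once, since five heavy atoms, including two oxygens and two hydrogen-bond acceptors, leave and two carbons enter, and no measurement available here explains why the number falls.

This single pair cannot separate the loss of the oxygens from the change in the size of the group, and it also leaves open whether the same step would appear on a different core. A chain carrying one methoxy group, an amine or a carboxylic acid, or a longer chain such as hexyl, would be needed to show which feature of the chain tracks with the effect.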